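The source may hold more compounds than are shown below. What is called first, only, known or untested is meant among the compounds shown, and "the series" means these compounds.

Three compounds share one core and differ only in the aryl group on the five-membered ring. In a functional assay on SSMC-7721 cells (Homo sapiens) for antiproliferative activity, read by CCK-8 assay, with a stated time of 48 h (on this read-out lower numbers stand for stronger inhibition and higher numbers for weaker inhibition), compound 1 `O=c1c2ccccc2[se]n1-c1nnc(-c2ccc(Br)cc2)s1` gives 68200 nM, compound 2 `O=c1c2ccccc2[se]n1-c1nnc(-c2ccccc2Cl)s1` gives 40200 nM, and compound 3 `Cc1cccc(-c2nnc(-n3[se]c4ccccc4c3=O)s2)c1` gives 17800 nM, the lowest of the three numbers; the step of a 2.3-fold lower number from compound 2 to compound 3 (0.35 log units; beyond the scatter) is modest, while a 1.7-fold lower number from compound 1 to compound 2 (0.23 log units; within the scatter) stays within the scatter. Compound 4 `O=c1c2ccccc2[se]n1-c1nnc(-c2ccccc2Br)s1` is reached from compound 3 by the change (2-bromophenyl in place of 3-methylphenyl on an aromatic carbon). The closest guide is the reverse of a 2.3-fold lower number from compound 2 to compound 3 (0.35 log units; beyond the scatter), since compound 2 also carries a halogen at the same position of the phenyl ring, and a 1.7-fold lower number from compound 1 to compound 2 (0.23 log units; within the scatter) suggests swapping one halogen for another changes little. A modest rise, a 2.1-fold higher number from compound 3 to compound 4 (0.33 log units; beyond the scatter), is therefore expected, and compound 4 is estimated at 38000 nM, within 17000 nM to 85000 nM.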

Compound 4, half-maximal inhibitory concentration: 27400 nM
Compound 4: the middle estimate sits 1.4-fold (0.14 log units) above what was measured; low and high end bracket the measured number.
By their numbers in this assay, from the lowest: compounds 3, 4, 2 and 1 (each within the scatter of the next, the first and the last beyond it).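

In this assay, the new 2-bromophenyl group cannot be told apart from the 3-methylphenyl group (a 1.5-fold higher number from compound 3 to compound 4 (0.19 log units; within the scatter)) or from the 2-chlorophenyl group (a 1.5-fold lower number from compound 2 to compound 4 (0.17 log units; within the scatter)). So swapping the halogen on this phenyl ring, or replacing the halogen-bearing ring with the methyl-bearing one, gives no clear change here. Moving the bromine does register: 2-bromophenyl in place of 4-bromophenyl gives a modest step (a 2.5-fold lower number from compound 1 to compound 4 (0.40 log units; beyond the scatter)). Nothing available here explains these differences. As far as these compounds go, how an amine or a carboxylic acid on this phenyl ring would behave remains open.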